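Permeability of compound 4 from three close analogues

The source may report more compounds than this note shows. Statements on the series, on what has been measured and on what is new or still open speak of the compounds shown alone.

Measured so far in an ADME assay on Caco-2 cells (Homo sapiens) for permeability, in the apical to basolateral direction; a lower number here means that the compound crosses the layer more slowly, a higher number that the compound crosses the layer faster:
- compound 1 `CCC(=O)N1CCC(CN(C2Cc3cc(C#N)ccc3N(Cc3cncn3C)C2)S(=O)(=O)c2ccccn2)CC1` gives 0.5 10^-6 cm/s
- compound 2 `Cn1cncc1CN1CC(N(CC2CCN(C(=O)C3CC3)CC2)S(=O)(=O)c2ccccn2)Cc2cc(C#N)ccc21` gives 0.5 10^-6 cm/s
- compound 3 `Cn1cncc1CN1CC(N(CC2CCN(C(=O)Nc3ccc(Br)cc3)CC2)S(=O)(=O)c2ccccn2)Cc2cc(C#N)ccc21` gives 0.6 10^-6 cm/s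

Compound 2 stands level with compound 1 at the digits shown, and the two together hold the lowest numbers of the three; its nearest neighbour is compound 1 with no change at the digits printed from compound 1 to compound 2 (within the scatter), its furthest is compound 3 with a 1.2-fold higher number from compound 2 to compound 3 (0.08 log units; within the scatter). Compound 4 `CCNC(=O)N1CCC(CN(C2Cc3cc(C#N)ccc3N(Cc3cncn3C)C2)S(=O)(=O)c2ccccn2)CC1` differs from compound 2 at the carbonyl carbon only: ethylamino in place of cyclopropyl on a carbonyl carbon. The measured steps at this same position, no change at the digits printed from compound 1 to compound 2 (within the scatter) and a 1.2-fold higher number from compound 1 to compound 3 (0.08 log units; within the scatter), all stayed within the scatter. Compound 4 is therefore expected to show no change at the digits printed from compound 2 to compound 4 (within the scatter) in this assay. Compound 4 is estimated at 0.5 10^-6 cm/s, with a range from 0.3 10^-6 cm/s to 0.9 10^-6 cm/s.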

Compound 4, apparent permeability: 0.6 10^-6 cm/s
The estimate for compound 4 lay 1.2-fold (0.08 log units) below the measured number; the range from low to high includes it.
By their numbers in this assay, from the lowest: compounds 1, 2, 3 and 4 (each within the scatter of the next).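

Ethylamino in place of cyclopropyl removes the ring and adds a hydrogen-bond donor on the carbonyl carbon, and in this assay this gives a 1.2-fold higher number from compound 2 to compound 4 (0.08 log units; within the scatter). Ethylamino in place of ethyl gives a 1.2-fold higher number from compound 1 to compound 4 (0.08 log units; within the scatter), while ethyl in place of 4-bromophenyl on the amide-type nitrogen gives no change at the digits printed from compound 3 to compound 4 (within the scatter), so all four groups at this position stay within the scatter of each other. Nothing available explains this flat picture.

Still open, going by these compounds, is whether a group carrying a carboxylic acid or a free amine, or a much longer chain, on this carbonyl carbon would move the number beyond the scatter.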